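The source may report more compounds than this note shows. Statements on the series, on what has been measured and on what is new or still open speak of the compounds shown alone.

Measured so far in a physicochemical assay for lipophilicity, using the shake flask method, in phosphate buffer, measured as octanol-water partition, at pH 7.4; a lower number here means a more polar compound, a higher number a more lipophilic compound:
compound 1 `COc1cc(-c2cc(C(=O)O)c3ccccc3n2)ccc1OCC(=O)Nc1ccccc1` gives 0.7
compound 2 `COc1cc(-c2cc(C(=O)O)c3ccccc3n2)ccc1OCC(=O)Nc1ccccc1F` gives 0.9
compound 3 `COc1cc(-c2cc(C(=O)O)c3ccccc3n2)ccc1OCC(=O)Nc1ccccc1C(F)(F)F` gives 1.3

Compound 3 stands highest of the three numbers in this assay. The nearest is compound 2, with the step of a number 0.40 log units higher from compound 2 to compound 3 (beyond the scatter) lying beyond the scatter; the furthest is compound 1, with the step of a number 0.60 log units higher from compound 1 to compound 3 (beyond the scatter) also beyond the scatter. The step of a number 0.20 log units higher from compound 1 to compound 2 (within the scatter) stays within the scatter.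

Compound 4 `COc1cc(-c2cc(C(=O)O)c3ccccc3n2)ccc1OCC(=O)NCc1ccccc1` differs from compound 3 in that (benzyl in place of 2-(trifluoromethyl)phenyl on an amide-type nitrogen). Among the measured compounds shown here, none of the measured steps covers this change directly: all three concern substituents on the aromatic carbon of the phenyl group, whereas here the whole group on the amide nitrogen is exchanged. What bears on it is that the trifluoromethyl group, with its three fluorine atoms, accounts for the rise from compound 1 to compound 3, and that group leaves. The entering benzyl adds one carbon without any fluorine. The expectation is therefore a step downward from compound 3, of a size comparable to the difference between compound 1 and compound 3, expected as a number 0.60 log units lower from compound 3 to compound 4 (beyond the scatter) in this assay. Compound 4 is estimated at 0.7, with a range of 0.3 to 1.1.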

Compound 4, distribution coefficient: 0.4
Beside the measured number, compound 4's estimate is 0.30 log units above it; the range from low to high includes it.
By their numbers in this assay, from the lowest: compounds 4, 1 and 2 (each within the scatter of the next, the first and the last beyond it); then compound 3.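

Until now, only substituents on the phenyl group had varied; here the group on the amide-type nitrogen itself changes, and in this assay this gives the largest step in the series, a number 0.90 log units lower from compound 3 to compound 4 (beyond the scatter), along with a number 0.50 log units lower from compound 2 to compound 4 (beyond the scatter). Against the unsubstituted phenyl, the same kind of exchange gives a number 0.30 log units lower from compound 1 to compound 4 (within the scatter), so this assay does not separate benzyl from phenyl at this nitrogen, and the two larger steps are seen only where the group that leaves carries fluoro or trifluoromethyl. Nothing available gives a measured basis for the size of these steps.

Open, on these data alone, is whether fluoro or trifluoromethyl on the benzyl group would shift the number as they do on phenyl, since the series shows these two substituents only on phenyl. Also open, as far as these compounds go, is how this position responds to a longer chain such as 2-phenylethyl, to a ring-bearing group carrying an amine or a hydroxyl, or to a simple alkyl group with no aromatic ring on the amide-type nitrogen.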